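The source may report more compounds than this note shows. Statements on the series, on what has been measured and on what is new or still open speak of the compounds shown alone.

Working notes on the series sharing one core. Compound 1 `COc1ccccc1N1C(=O)CSC1c1cc(F)cc(C(=O)O)c1`, carrying a free acid, gives 0% in a functional assay on SJSA-1 cells (Homo sapiens) for inhibition, read by CCK-8 assay, with a stated time of 72 h, tested at 1 uM; on this read-out higher numbers stand for more inhibition at the one concentration tested (going by the name of the read-out) and lower numbers for less inhibition. Compound 2 `COc1ccc(C)cc1N1C(=O)CSC1c1cccc(C(=O)NCCCCc2ccccc2)c1` gives 79% in this assay, far beyond the scatter above compound 1 and within the scatter of compound 3 `CCOc1ccccc1N1C(=O)C(C)SC1c1cccc(C(=O)NCCCCc2ccccc2)c1`, which gives 85% in this assay. Compound 4 `O=C(NCCCCc1ccccc1)c1cccc(C2SCC(=O)N2c2ccccc2)c1` is not yet measured; it differs from compound 2 by phenyl in place of 2-methoxy-5-methylphenyl on an amide-type nitrogen in a ring. For the measured compounds named here, no measured pair isolates this change, and both measured amides, compound 2 and compound 3, carry a substituted ring on that nitrogen. A modest downward step in this assay is expected, possibly within the scatter, since compound 3 sharing the amide chain gives 85%. Compound 4 is estimated at 65% with a range from 35% to 85%. The expected step is a number 14 percentage points lower from compound 2 to compound 4 (beyond the scatter).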

Compound 4, a percentage reported as inhibition, at one concentration (the size of the read-out at that concentration, not a potency): 73%
The estimate for compound 4 lay 8 percentage points below the measured number, within the range that was stated.
By their numbers in this assay, from the lowest: compound 1; then compounds 4, 2 and 3 (each within the scatter of the next, the first and the last beyond it).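

For the compounds shown here, compound 4 gives the first pair that isolates this position: with phenyl in place of 2-methoxy-5-methylphenyl on the amide-type nitrogen in a ring, this assay shows a number 6 percentage points lower from compound 2 to compound 4 (within the scatter). With the phenylbutyl amide chain present, the methoxy and methyl groups are therefore not required for inhibition at the one concentration tested. Nothing shown here explains this outcome.

Open, as far as these compounds go, is how a pyridine ring or an aminophenyl group on this nitrogen would read. A single-concentration read-out also leaves open whether compound 2 and compound 4 differ in potency.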